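The source may hold more compounds than are shown below. What is called first, only, known or untested is meant among the compounds shown, and "the series" means these compounds.

Working notes on the series.

Compound 1 `CO/N=C(\C)c1ccc(Sc2cc(F)cc(C3CCOCC3)c2)cc1` is the reference point. Going by the values given here, in a functional assay (blood) for inhibition, with Homo sapiens as the target (a higher number here means a weaker inhibitor, a lower number a stronger inhibitor), compound 1 gives 110 nM, the lowest of the three numbers measured so far. Compound 2 `C/C(=N\OCc1ccncc1)c1ccc(Sc2cc(F)cc(C3CCOCC3)c2)cc1` gives 300 nM in this assay, and compound 3 `CN(C)/C(=N\O)c1ccc(Sc2cc(F)cc(C3CCOCC3)c2)cc1` gives 280 nM. Both steps away from compound 1 go in the same direction: a 2.7-fold higher number from compound 1 to compound 2 (0.44 log units; beyond the scatter), and a 2.5-fold higher number from compound 1 to compound 3 (0.41 log units; beyond the scatter).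

Compound 4 `C/C(=N\OCC#N)c1ccc(Sc2cc(F)cc(C3CCOCC3)c2)cc1` has not yet been measured in this assay. It differs from compound 1 in one place: cyano in place of hydrogen on a saturated chain carbon bound to an oxygen. The step from compound 1 to compound 2 bears most directly on this change, since it also replaces hydrogen on a saturated chain carbon bound to an oxygen, there with pyridin-4-yl, and it cost a 2.7-fold higher number from compound 1 to compound 2 (0.44 log units; beyond the scatter). Cyano is a far smaller group than pyridin-4-yl, so a smaller penalty, or none beyond the scatter, is expected. Compound 4 is therefore estimated at 180 nM in this assay, with a range of 90 nM to 400 nM, which corresponds to an expected step of a 1.6-fold higher number from compound 1 to compound 4 (0.21 log units; within the scatter).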

Compound 4, half-maximal inhibitory concentration: 20 nM
Compound 4: the middle estimate sits 9.0-fold (0.95 log units) above what was measured, outside the stated range (below it).
By their numbers in this assay, from the lowest: compound 4; then compound 1; then compounds 3 and 2 (each within the scatter of the next).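

In this assay, substitution on the saturated chain carbon bound to an oxygen carries no penalty in itself: cyano in place of hydrogen gives a 5.5-fold lower number from compound 1 to compound 4 (0.74 log units; beyond the scatter), so the direction of the step at this place depends on the entering group. Cyano in place of pyridin-4-yl gives a 15-fold lower number from compound 2 to compound 4 (1.18 log units; beyond the scatter), and the change on the aromatic carbon gives a 14-fold lower number from compound 3 to compound 4 (1.15 log units; beyond the scatter), which leaves the cyanomethoxy group as the only one shown to fall below compound 1. No supporting data bear on the origin of this gain.

The compounds shown leave open whether the gain belongs to the nitrile itself or would also appear with an amide, a carboxylic acid or a longer chain ending in a nitrile at this place. They also leave open whether it persists when other parts of the core of compound 1 change.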